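The compounds below may be only part of what the source reports. "The series", "measured", "known", "first", "only" and "open" are said of these compounds alone.

Among the compounds with values here, in an in vitro ADME assay on microsomes from liver (Mus musculus) for pharmacokinetics (a lower number here means slower removal, a higher number faster removal of the compound), compound 2 `CC(C)C1CCNC(=O)C(N(Cc2ccc(C(=O)NC3CC3)cc2)S(=O)(=O)c2ccc(Cl)cc2)C1` gives 203 mL.min-1.g-1, the lower of the two numbers measured so far, while compound 1 `CC1(C)CCNC(=O)[C@H](N(Cc2ccc(C(=O)NC3CC3)cc2)S(=O)(=O)c2ccc(Cl)cc2)C1` gives 655 mL.min-1.g-1. Compound 3 `O=C(NC1CC1)c1ccc(CN(C2CC(C(F)(F)F)CCNC2=O)S(=O)(=O)c2ccc(Cl)cc2)cc1` has trifluoromethyl in place of isopropyl on a saturated ring carbon of compound 2: trifluoromethyl in place of isopropyl on a saturated ring carbon. Within the data shown here, only one measured step bears on that ring carbon, a 3.2-fold lower number from compound 1 to compound 2 (0.51 log units; beyond the scatter), a modest change beyond the scatter. Among the measured compounds shown here, no measured compound carries fluorine there, so this step is a guide to size and says little about direction. A step of comparable size is nevertheless expected, towards a lower number in this assay, although a result within the scatter remains possible. The expected change is a 2.3-fold lower number from compound 2 to compound 3 (0.35 log units; beyond the scatter). For compound 3, the estimated value is 90 mL.min-1.g-1, with an expected range of 40 mL.min-1.g-1 to 210 mL.min-1.g-1.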

Compound 3, intrinsic clearance in microsomes: 39 mL.min-1.g-1
For compound 3 the middle estimate is 2.3-fold (0.36 log units) above the measured one; the measured number lies below the stated range.
By their numbers in this assay, from the lowest: compound 3; then compound 2; then compound 1.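

In this assay, trifluoromethyl in place of isopropyl on this saturated ring carbon gives a 5.2-fold lower number from compound 2 to compound 3 (0.72 log units; beyond the scatter), a second step towards a lower number at a position previously represented only by the change from 5,5-dimethyl-2-oxoazepan-3-yl to 5-isopropyl-2-oxoazepan-3-yl. Taken from the dimethyl group, the change to 2-oxo-5-(trifluoromethyl)azepan-3-yl gives a 17-fold lower number from compound 1 to compound 3 (1.23 log units; beyond the scatter), the only large step among the three compounds, and compound 3 has the lowest number of them. Nothing available explains why the number falls with this change.

Going by these compounds, it remains open whether a methyl, difluoromethyl or nitrile group on this ring carbon would give a number nearer that of compound 2 or compound 3. On these data alone, compound 2 and compound 3 are drawn without a set configuration at their ring carbons, so the contribution of each stereoisomer to these numbers also remains open.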